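The source may hold more compounds than are shown below. What is called first, only, known or untested is meant among the compounds shown, and "the series" means these compounds.

Compound 1 `CCCCOc1ccc(-c2nc3ncccn3c2NC2CCCCCC2)cc1` gives 26000 nM in a toxicity assay on A549 cells (Homo sapiens) for cytotoxicity, read by luminescence and CellTiter-Glo, with a stated time of 48 h; a lower number here means that less compound is tolerated, a higher number that more compound is tolerated.
Compound 2 `CCCCOc1ccc(-c2nc3ncccn3c2NCC2CCCCC2)cc1` gives 35000 nM in this assay.
Compound 3 `CCCCOc1ccc(-c2nc3ncccn3c2NC(C)C)cc1` gives 68000 nM in this assay.

Compound 3 has the highest of the three numbers, so it is the one of which the cells tolerate most. One of the steps that lead to it is a 2.6-fold higher number from compound 1 to compound 3 (0.42 log units; beyond the scatter), a modest step beyond the scatter, while the other is a 1.9-fold higher number from compound 2 to compound 3 (0.29 log units; within the scatter), which stays within the scatter; the step between the two larger groups, a 1.3-fold higher number from compound 1 to compound 2 (0.13 log units; within the scatter), is also within the scatter.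

Compound 4 `CCCCOc1ccc(-c2nc3ncccn3c2N)cc1` takes the next step in the same direction: hydrogen in place of isopropyl on a nitrogen on an aromatic ring. Going by the values given here, the steps that bear on it are those where a smaller group replaced a larger one on that nitrogen, namely a 2.6-fold higher number from compound 1 to compound 3 (0.42 log units; beyond the scatter) and a 1.9-fold higher number from compound 2 to compound 3 (0.29 log units; within the scatter). Both moved the number upward, one modestly, one within the scatter. Removing the last group entirely is a larger structural change than either, so a further rise in this assay is expected, of similar or somewhat larger size, though with real uncertainty.

Compound 4 is therefore expected to give about 100000 nM, a step of a 1.5-fold higher number from compound 3 to compound 4 (0.17 log units; within the scatter), with a plausible range from 50000 nM to 200000 nM.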

Compound 4, half-maximal cytotoxic concentration: > 100000 nM
Compound 4: no number, only a limit; the forecaster's own chance of this, stated with the estimate: 25%; the middle value sits exactly at the limit.
By their numbers in this assay, from the lowest: compounds 1, 2 and 3 (each within the scatter of the next, the first and the last beyond it). At a limit, above all of these: compound 4.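

In this assay compound 4 gives > 100000 nM, which is a limit of the assay and not a number, and it is the only such reading among these compounds: the limit of > 100000 nM in this assay, at which 1 of the 4 values shown sits.

What this adds is that the nitrogen on the aromatic ring can lose its last carbon group, isopropylamino becoming amino, without the cells tolerating less compound; read at its floor, however, an at least 1.4-fold higher number from compound 3 to compound 4 (0.16 log units; that floor lies within the scatter) does not by itself establish a rise over the isopropyl compound. Against the larger groups the picture is firmer, since an at least 2.8-fold higher number from compound 2 to compound 4 (0.45 log units; beyond the scatter) and an at least 3.8-fold higher number from compound 1 to compound 4 (0.58 log units; beyond the scatter) both clear the scatter, whereas among the earlier compounds only the step from cycloheptyl to isopropyl did.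

On these data alone, how far the true value of compound 4 lies past the limit stays unknown, so the full size of all these steps cannot be given. Also open, as far as these compounds go, is how a small methyl or ethyl group on this nitrogen would compare with hydrogen and isopropyl, and whether an acetyl group or a chain ending in a carboxylic acid there would follow the same trend as the plain carbon groups.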